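Ethylamino for 2-chloroethyl on the carbonyl carbon

A few compounds are considered here, and "the series" means these few. Any claim that something is new, unique, unknown or untested is made for them only; others in the source may bear on it.

Three amides on one shared core have been measured in a functional assay on M21 cells (Homo sapiens) for antiproliferative activity, read by sulforhodamine B assay, with a stated time of 48 h; on this read-out lower numbers stand for stronger inhibition and higher numbers for weaker inhibition. Compound 1 `CCC(=O)Nc1ccc(S(=O)(=O)Oc2ccccc2I)cc1` gives 11000 nM. Compound 2 `CC(C)C(=O)Nc1ccc(S(=O)(=O)Oc2ccccc2I)cc1` gives 13000 nM. Compound 3 `O=C(CCCl)Nc1ccc(S(=O)(=O)Oc2ccccc2I)cc1` gives 12000 nM. The steps between them are small: a 1.2-fold higher number from compound 1 to compound 2 (0.07 log units; within the scatter), a 1.1-fold higher number from compound 1 to compound 3 (0.04 log units; within the scatter) and a 1.1-fold lower number from compound 2 to compound 3 (0.03 log units; within the scatter). Compound 3 thus holds the second highest of the three numbers, with compound 2 nearest and compound 1 furthest, both within the scatter; on these numbers the three compounds cannot be told apart.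

Compound 4 `CCNC(=O)Nc1ccc(S(=O)(=O)Oc2ccccc2I)cc1` is not yet measured. Against compound 3 the change is ethylamino in place of 2-chloroethyl on a carbonyl carbon, read one bond further out as (2-chloroethyl)carbonyl to ethylcarbamoyl. The measured steps bear on it only loosely: the steps from compound 1 to compound 2 and to compound 3 alter the chain on the carbonyl carbon, and the step from compound 2 to compound 3 exchanges one chain for another, all within the scatter. Among the measured compounds shown here, no measured compound carries a hydrogen-bond donor at this place, so that part of the change is uncovered. Compound 4 is expected to move only a 1.2-fold higher number from compound 3 to compound 4 (0.07 log units; within the scatter) in this assay, within the scatter. The estimate for compound 4 is 14000 nM, in the range 6000 nM to 35000 nM.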

Compound 4, half-maximal inhibitory concentration: 5600 nM
The estimate for compound 4 lay 2.5-fold (0.40 log units) above the measured number; measured number outside the range, below it.
By their numbers in this assay, from the lowest: compounds 4, 1, 3 and 2 (each within the scatter of the next, the first and the last beyond it).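

In this assay, the place on the carbonyl carbon whose other neighbour is the amide-type nitrogen now gives steps beyond the scatter, as modest as they are, with a 2.1-fold lower number from compound 3 to compound 4 (0.33 log units; beyond the scatter) and a 2.3-fold lower number from compound 2 to compound 4 (0.37 log units; beyond the scatter) on entry of ethylamino, whereas exchanges among the carbon chains of compounds 1, 2 and 3 had all stayed within it. The pattern is incomplete, since ethylamino in place of ethyl gives a 2.0-fold lower number from compound 1 to compound 4 (0.29 log units; within the scatter) and that step remains within the scatter, so compound 1 goes against it and compound 4 cannot be separated from compound 1 on these numbers. Ethylamino is also the only group here that counts a hydrogen-bond donor at this place, but no measurement at hand accounts for the difference in the numbers.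

Open, from the compounds shown here alone, is whether the nitrogen itself or the hydrogen on it goes with the lower numbers, which dimethylamino on the same carbonyl carbon would bear on directly. Also open, going by these compounds, is how far the result extends to other groups on this nitrogen, such as methylamino, a longer chain like butylamino, or a phenylamino group.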